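Furan-2-yl Replacing 4-Chlorophenyl on the Amide Carbonyl

A few compounds are considered here, and "the series" means these few. Any claim that something is new, unique, unknown or untested is made for them only; others in the source may bear on it.

Of the compounds shown here, two sharing the same core have been measured. Compound 1 `CCN1CCN(c2cc(C)c3cc(NC(=O)c4ccc(Cl)cc4)ccc3n2)CC1` and compound 2 `Cc1cc(N2CCN(C(C)C)CC2)nc2ccc(NC(=O)c3ccc(Cl)c(Cl)c3)cc12` were both tested in a functional assay on MCF7 cells (Homo sapiens) for antiproliferative activity, read by MTT assay, with a stated time of 72 h; on this read-out higher numbers stand for weaker inhibition and lower numbers for stronger inhibition. In this assay compound 1 gives 1530 nM, and compound 2 gives 1710 nM; the two numbers lie within the usual scatter of each other, so neither can be set apart from the other. Compound 3 `CCN1CCN(c2cc(C)c3cc(NC(=O)c4ccco4)ccc3n2)CC1` has not yet been measured. It differs from compound 1 in one place (furan-2-yl in place of 4-chlorophenyl on a carbonyl carbon). For the measured compounds named here, no measured pair in this set carries the same change, so the step from compound 1 to compound 3 can only be estimated. The step of a 2.0-fold higher number from compound 1 to compound 3 (0.29 log units; within the scatter) is expected to be modest and directed toward higher numbers, though it may fall within the scatter. Compound 3 is therefore expected to give about 3000 nM in this assay, within a range from 1200 nM to 8000 nM.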

Compound 3, half-maximal inhibitory concentration: 41200 nM
For compound 3 the middle estimate is 14-fold (1.14 log units) below the measured one; the whole stated range lies below it.
By their numbers in this assay, from the lowest: compounds 1 and 2 (each within the scatter of the next); then compound 3.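

At the carbonyl carbon whose other neighbour is the amide-type nitrogen, the group is not freely exchangeable: in this assay, furan-2-yl in place of 4-chlorophenyl gives a 27-fold higher number from compound 1 to compound 3 (1.43 log units; beyond the scatter), a large step beyond the scatter. For the compounds shown here, this is the first single-change reading at this position, since compound 1 and compound 2 differ in more than one place. No measurement at hand explains why the step is so large.

The compounds shown leave open whether the step follows from losing the chlorine or from changing the ring; an unsubstituted phenyl or a thiophen-2-yl on the same carbonyl would separate the two. They also leave open whether furan-2-yl would carry a step of similar size in the setting of compound 2.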